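The compounds below may be only part of what the source reports. "The series", "measured", "known", "first", "only" and "open" are said of these compounds alone.

This set turns on a cytotoxicity read-out in an ADME assay on N2a cells (Mus musculus) for cytotoxicity, read by MTT assay; a higher number here means a weaker inhibitor, a lower number a stronger inhibitor. Compound 1, with the structure `C#CC[C@@H]1C[C@H](n2cccc2C(=O)C(F)(F)F)C(=O)O1`, gives in this assay a value of > 100000 nM, which is a limit of the assay rather than a measured number. Compound 2, with the structure `CC(=O)c1cccn1[C@H]1C[C@@H](Cc2cn(Cc3ccccc3)nn2)OC1=O`, gives in this assay a value of 91600 nM. Within this small set, compound 2 holds the only measured number, and it stands close to the limit of > 100000 nM in this assay, at which 1 of the 2 values shown sits, so the two compounds shown are not separated by anything beyond the usual scatter.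

Compound 3, with the structure `CC(=O)c1cccn1[C@H]1C[C@H](Cc2cn(Cc3ccccc3)nn2)OC1=O`, has not yet been measured. Its relation to compound 2 is the two compounds have the same atoms and bonds and differ only in configuration as drawn: 1 of 2 stereo elements differ; a stereocentre at a saturated ring carbon is drawn S in compound 2 and R in compound 3: the two compounds have the same atoms and bonds and differ only in configuration as drawn, with a stereocentre at a saturated ring carbon drawn S in compound 2 and R in compound 3.

Going by the values given here, no measured step between two compounds exists here to guide a prediction, so the expectation rests on compound 2 alone. In this assay compound 3 is expected to give about 100000 nM, with a plausible range from 45000 nM to 250000 nM. The expected step from compound 2 to compound 3 is a 1.1-fold higher number from compound 2 to compound 3 (0.04 log units; within the scatter), essentially none beyond the scatter.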

Compound 3, half-maximal inhibitory concentration: 66900 nM
Compound 3: the middle estimate sits 1.5-fold (0.17 log units) above what was measured; the range from low to high includes it.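

Changing one stereocentre at a saturated ring carbon, drawn S in compound 2 and R in compound 3, gives in this assay a 1.4-fold lower number from compound 2 to compound 3 (0.14 log units; within the scatter), so at this carbon the configuration as drawn does not separate the two compounds in this read-out. Going by these compounds alone, this is the first step in the set that can be read at all, and it isolates a single change, with nothing else in the structure moving along with it: the fact that compounds 2 and 3 differ only in the configuration as drawn. The set's one limit belongs to compound 1, and it remains a limit of the assay rather than a number, so the new step says nothing about that compound: the limit of > 100000 nM in this assay, at which 1 of the 3 values shown sits.

The compounds shown leave open whether the other stereo element, which compound 2 and compound 3 share, would matter as little in this assay if it were drawn the other way. They also leave open how this read-out would respond to a group of a different kind on the shared core, such as an amine or a carboxylic acid.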